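Cyano in place of chloro on the shared core

The source may report more compounds than this note shows. Statements on the series, on what has been measured and on what is new or still open speak of the compounds shown alone.

In an ADME assay on L6 cells (Rattus norvegicus) for cytotoxicity (on this read-out higher numbers stand for weaker inhibition and lower numbers for stronger inhibition), compound 1 `CS[C@H]1O[C@@H](n2cnc3c(N)nc(Cl)nc32)[C@H](O)[C@@H]1O` gives 271000 nM. Compound 2 `C[C@H]1O[C@@H](n2cnc3c(N)nc(N)nc32)[C@H](O)[C@@H]1O` gives 338000 nM and compound 3 `C[C@H]1O[C@@H](n2cnc3c(N)nc(C#N)nc32)[C@H](O)[C@@H]1O` gives 177000 nM. All three numbers lie within the scatter of one another, so compound 1 holds no separate rank. Compound 4 `CS[C@H]1O[C@@H](n2cnc3c(N)nc(C#N)nc32)[C@H](O)[C@@H]1O` is still unmeasured and differs from compound 1 by cyano in place of chloro on an aromatic carbon, with cyano in place of chloro on an aromatic carbon. For the measured compounds named here, the one bearing step is a 1.9-fold lower number from compound 2 to compound 3 (0.28 log units; within the scatter), where cyano replaces amino rather than chloro. Going by the values given here, no direct chloro-to-cyano step has been measured, so no change beyond the scatter is expected. For compound 4 the estimated value is 210000 nM, with an expected range of 110000 nM to 380000 nM. The expected change is a 1.3-fold lower number from compound 1 to compound 4 (0.11 log units; within the scatter).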

Compound 4, half-maximal inhibitory concentration: 153000 nM
Beside the measured number, compound 4's estimate is 1.4-fold (0.14 log units) above it; measured number inside the range.
By their numbers in this assay, from the lowest: compounds 4, 3, 1 and 2 (each within the scatter of the next, the first and the last beyond it).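

In this assay, for the compounds shown here, the first direct reading of chloro to cyano on the aromatic carbon between two ring nitrogen atoms is a 1.8-fold lower number from compound 1 to compound 4 (0.25 log units; within the scatter) and stays short of a separable change at this position. With cyano held on the shared core, methylsulfanyl in place of methyl on a saturated ring carbon gives a 1.2-fold lower number from compound 3 to compound 4 (0.06 log units; within the scatter) and adds no separable change either. No supporting data explain either step.

Going by these compounds, whether a carboxylic acid at this position, or a longer chain in place of methylsulfanyl on the saturated ring carbon, would move the number beyond the scatter remains open.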